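Acetamido in Place of Phenyl: What Compound 4 May Show

The source may report more compounds than this note shows. Statements on the series, on what has been measured and on what is new or still open speak of the compounds shown alone.

Of the compounds shown here, three sharing one core have been tested in a functional assay on the whole organism for inhibition, with Rattus norvegicus as the target, with stated times of 1 h and 3.5 h, at a dose of 100 mg/kg by the oral route; on this read-out lower numbers stand for less inhibition and higher numbers for more inhibition at the one dose given (going by the name of the read-out). Compound 1, `Cc1ncc(C)c(-c2ccccc2)n1`, gives 12% in this assay. Compound 2, `CC(C)(C)c1nc(N)ncc1-c1ccccc1`, gives 46%. For compound 3, `CC(C)(C)c1nc(-c2ccccc2)ncc1-c1ccccc1`, this assay reports only a limit rather than a number, < 5%. That is the limit of < 5% in this assay, at which 1 of the 3 values shown sits, so compound 3 stands at the bottom of the numbers shown, and the exact size of its inhibition is unknown.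

One measured step changes a single place: a number at least 41 percentage points lower from compound 2 to compound 3 (beyond the scatter). Putting a phenyl where the amino stood removed most of the inhibition seen for compound 2.

Compound 4, `CC(=O)Nc1ncc(-c2ccccc2)c(C(C)(C)C)n1`, has not yet been measured. Its difference from compound 3 is acetamido in place of phenyl on an aromatic carbon. This change largely reverses the measured step: the phenyl leaves again, and a small group with one hydrogen-bond donor and one hydrogen-bond acceptor takes its place, as the amino of compound 2 did. Among the compounds with values here, the step from compound 2 to compound 3 is the only guide, and it was large. Compound 4 is therefore expected to regain inhibition in this assay, with an estimated step of a number at least 25 percentage points higher from compound 3 to compound 4 (beyond the scatter), upward and beyond the scatter, though acetamido is not amino and a full return to compound 2 is uncertain. Compound 4 is estimated at 30%, within a range from 5% to 55%.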

Compound 4, a percentage reported as inhibition, in the whole organism at one dose (the size of the read-out at that dose, not a potency): 29%
Compound 4: the middle estimate sits 1 percentage points above what was measured; the measured number falls inside the stated range.
By their numbers in this assay, from the lowest: compound 1; then compound 4; then compound 2. At a limit, below all of these: compound 3.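

Compound 4 shows that the place between two ring nitrogen atoms can hold more than a bare amino group and still give inhibition: acetamido in place of phenyl gives a number at least 24 percentage points higher from compound 3 to compound 4 (beyond the scatter) in this assay. The amino group of compound 2 and its acetylated form are still not interchangeable here, since acetyl in place of hydrogen on that nitrogen gives a number 17 percentage points lower from compound 2 to compound 4 (beyond the scatter). Compound 3 is reported only as a limit, so the full size of the rise to compound 4 stays unknown: the limit of < 5% in this assay, at which 1 of the 4 values shown sits.

The compounds shown leave open whether inhibition depends on a nitrogen attached to the ring or simply on the phenyl being absent; a methyl group, a methoxy group or a plain hydrogen at this place would help separate those two readings. They also leave open how far the acyl part can grow or change, as a longer chain such as propionamido or a methyl carbamate on the same nitrogen would show whether the drop from the free amino group continues or levels off.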